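A Branched Chain Swapped for a Hydroxypropyl Chain

This account rests on a few compounds, and the source may have more. Where it says the series, first, only, none or still open, it means among the compounds named here.

In an in vitro functional assay on cells for agonist activity at Bombesin receptor subtype-3 (Mus musculus), read by luminescence and calcium flux (on this read-out higher numbers stand for an effect only at larger amounts of compound and lower numbers for an effect already at smaller amounts), compound 1 `CCCCc1cnc(C(C)Cc2ccc(-c3ccccc3C(=O)O)cc2)[nH]1` gives 184 nM. Compound 2 `CCCCc1cnc(C(CCC)Cc2ccc(-c3ccccc3C(=O)O)cc2)[nH]1` gives 165 nM in this assay, and compound 3 `CCCCc1cnc(C(Cc2ccc(-c3ccccc3C(=O)O)cc2)C(C)C)[nH]1` gives 2240 nM. Compound 3 thus stands at the highest number of the three, with compound 1 nearest and compound 2 furthest. Compound 4 `CCCCc1cnc(C(CCCO)Cc2ccc(-c3ccccc3C(=O)O)cc2)[nH]1` differs from compound 3 in one place: 3-hydroxypropyl in place of isopropyl on a saturated chain carbon bound to an aromatic carbon and a saturated chain carbon. Within the data shown here, two measured steps bear on this change. The step of a 12-fold higher number from compound 1 to compound 3 (1.09 log units; beyond the scatter) and the step of a 14-fold higher number from compound 2 to compound 3 (1.13 log units; beyond the scatter) both show a large rise in the number when isopropyl enters this position, while the step of a 1.1-fold lower number from compound 1 to compound 2 (0.05 log units; within the scatter) shows that a straight chain of a different length changes little. Among the measured compounds shown here, compound 4 replaces the branch with 3-hydroxypropyl, a straight chain of three carbons carrying one oxygen, so a return towards the numbers of compound 1 and compound 2 is expected, though the hydroxyl is something no measured compound carries, which widens the range. Compound 4 is expected to give about 250 nM in this assay, within 80 nM to 900 nM. That expected move is a 9.0-fold lower number from compound 3 to compound 4 (0.95 log units; beyond the scatter).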

Compound 4, half-maximal effective concentration: 238 nM
Beside the measured number, compound 4's estimate is 1.1-fold (0.02 log units) above it; low and high end bracket the measured number.
By their numbers in this assay, from the lowest: compounds 2, 1 and 4 (each within the scatter of the next); then compound 3.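

The step of a 9.4-fold lower number from compound 3 to compound 4 (0.97 log units; beyond the scatter) shows that the high number of compound 3 does not carry over to every three-carbon chain at this position: it goes with the isopropyl branch, not with the 3-hydroxypropyl chain. Among these compounds, the hydroxy group is also accepted here, a point the earlier compounds could not address, since the steps of a 1.4-fold higher number from compound 2 to compound 4 (0.16 log units; within the scatter) and a 1.3-fold higher number from compound 1 to compound 4 (0.11 log units; within the scatter) both stay within the scatter and leave compound 4 alongside compounds 1 and 2. Nothing measured here gives a reason for these numbers.

From the compounds shown here alone, it remains open whether an amine or a carboxylic acid at the end of this chain would be accepted as the hydroxy group is. A longer chain carrying a hydroxy group, or a hydroxy group on a branched chain, is also still to be judged.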